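An Ethyl for a Methyl on Two Related Cores

The source may hold more compounds than are shown below. What is called first, only, known or untested is meant among the compounds shown, and "the series" means these compounds.

Three compounds have been measured in a functional assay on MCF7 cells (Homo sapiens) for antiproliferative activity, read by MTT assay, with a stated time of 48 h; on this read-out higher numbers stand for weaker inhibition and lower numbers for stronger inhibition:

Compound 1 `C=C(c1ccc(OC)cc1NC(=O)CNC)c1ccc(OC)c2c1OC(C)(C)C=C2` gives 400 nM in this assay.
Compound 2 `C=C(c1ccc2c(c1)C=CC(C)(C)O2)c1ccc(OC)cc1NC(=O)CNC` gives 720 nM in this assay.
Compound 3 `C=C(c1ccc(OC)cc1NC(=O)CNCC)c1ccc(OC)c2c1OC(C)(C)C=C2` gives 2100 nM in this assay.

Compound 1 and compound 3 share one core and differ at a single point: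

methyl in place of hydrogen on a saturated chain carbon bound to an amine nitrogen

This change produced a 5.3-fold higher number from compound 1 to compound 3 (0.72 log units; beyond the scatter) in this assay, so the larger alkyl on the amine weakened the activity noticeably.

Compound 2 sits on a different core; the difference between the two cores is not broken down here. Its value in this assay and that of compound 1 lie within the usual scatter, so no order between them can be claimed.

The compound still to be measured is compound 4 `C=C(c1ccc2c(c1)C=CC(C)(C)O2)c1ccc(OC)cc1NC(=O)CNCC`. It is related to compound 2 exactly as compound 3 is related to compound 1:

methyl in place of hydrogen on a saturated chain carbon bound to an amine nitrogen

The two "place" descriptions are identical, so this is the same change carried onto the other core. Among the compounds with values here, with only one prior example, the expectation rests on it: compound 4 is expected to be weaker than compound 2, with a step of about a 4.9-fold higher number from compound 2 to compound 4 (0.69 log units; beyond the scatter) in this assay, because of the earlier 5.3-fold higher number from compound 1 to compound 3 (0.72 log units; beyond the scatter). On that basis compound 4 is estimated at 3500 nM in this assay, most likely between 1500 nM and 9000 nM. Whether the new core changes the size of the step remains to be seen.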

Compound 4, half-maximal inhibitory concentration: 3370 nM
For compound 4 the middle estimate is 1.0-fold (0.02 log units) above the measured one, and the stated range covers the measured number.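

In this assay, exchanging methylamino for ethylamino on the second core gave a 4.7-fold higher number from compound 2 to compound 4 (0.67 log units; beyond the scatter), so the larger alkyl on the amine weakened the activity here as well. Set beside the same exchange on the core of compound 1, the size of the step carries over from one core to the other: the same change on two cores in this assay, a 5.3-fold higher number (0.72 log units; beyond the scatter) from compound 1 to compound 3 and a 4.7-fold higher number (0.67 log units; beyond the scatter) from compound 2 to compound 4, 1.1-fold (0.05 log units) apart, within the scatter of two such steps This shows that, for these two pairs, the methyl to ethyl exchange behaves much the same on both cores, so the step seen on one core gave a fair guide to the other; it does not show why the ethyl group weakens activity, nor that the same step would appear on any further core or in any other test, as two pairs in a single assay are a very small base.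

The compounds shown leave open whether activity keeps falling as the group on the amine grows to a longer chain such as propyl or a branched one such as isopropyl, and whether a primary amine, with hydrogen in place of the methyl, would continue the trend in the other direction. They also leave open whether a cyclic amine such as pyrrolidine would give matching steps on both cores.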